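A Third Chlorine on the Dichloroacetanilide Core

This account rests on a few compounds, and the source may have more. Where it says the series, first, only, none or still open, it means among the compounds named here.

Two close relatives of one small amide have been tested for their ability to slow the growth of lung cancer cells. Compound 1 `O=C(Nc1ccccc1Cl)C(Cl)Cl` carries a single chloro group, and in a functional assay on A549 cells (Homo sapiens) for antiproliferative activity, read by MTT assay, with a stated time of 72 h (on this read-out higher numbers stand for weaker inhibition and lower numbers for stronger inhibition), compound 1 gives 50200 nM. Compound 2 `O=C(Nc1cccc(Cl)c1)C(Cl)Cl` carries its chloro group at a different spot of the same ring, and in this assay compound 2 gives 14800 nM. Of the two numbers, compound 2 holds the lower one, and compound 1 lies further away than repeated testing of one compound usually scatters.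

Compound 3 `O=C(Nc1cc(Cl)ccc1Cl)C(Cl)Cl` keeps everything compound 2 has and gains one more substituent: chloro in place of hydrogen on an aromatic carbon. Among the compounds with values here, no measured pair shows what such an added chloro does here, so the size of the step is open. The expectation is that the step of a 1.2-fold higher number from compound 2 to compound 3 (0.09 log units; within the scatter) stays within the usual scatter. Compound 3 is therefore estimated at 18000 nM, with a plausible range from 5000 nM to 60000 nM.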

Compound 3, half-maximal inhibitory concentration: 12400 nM
Compound 3: middle estimate off by 1.5-fold (0.16 log units), on the high side, and the stated range covers the measured number.
By their numbers in this assay, from the lowest: compounds 3 and 2 (each within the scatter of the next); then compound 1.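

In this assay, a chloro group placed ortho to a group of 6 heavy atoms and para to a chloro group gives a 1.2-fold lower number from compound 2 to compound 3 (0.08 log units; within the scatter), so adding it to compound 2 changes nothing that can be told apart from ordinary repeat variation. Seen from the other side, compound 3 also holds the chloro group that sets compound 2 apart from compound 1, and that addition gives a 4.0-fold lower number from compound 1 to compound 3 (0.61 log units; beyond the scatter), a modest gain that lies beyond the scatter. Among these three compounds, then, a second chloro group matters when added to compound 1 but not when added to compound 2.

Going by these compounds, whether a methyl, methoxy or amino group at the same ring position would behave like chloro remains open. Nothing available here explains why the two additions differ.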